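A few compounds are considered here, and "the series" means these few. Any claim that something is new, unique, unknown or untested is made for them only; others in the source may bear on it.

Compounds measured in a functional assay on MDA-MB-231 cells (Homo sapiens) for antiproliferative activity, read by XTT assay, with a stated time of 72 h; on this read-out higher numbers stand for weaker inhibition and lower numbers for stronger inhibition:
compound 1 `COc1ccc(-c2cc3ccccc3nc2/C=C/C(=O)c2ccc([N+](=O)[O-])cc2)cc1` gives 840 nM;
compound 2 `COc1ccc(-c2cc3ccccc3nc2/C=C/C(=O)c2ccccn2)cc1` gives 740 nM;
compound 3 `COc1ccc(-c2cc3ccccc3nc2/C=C/C(=O)c2ccsc2)cc1` gives 1060 nM.

Compound 3 has the highest of the three numbers, yet its gaps to the others, a 1.3-fold higher number from compound 1 to compound 3 (0.10 log units; within the scatter) and a 1.4-fold higher number from compound 2 to compound 3 (0.16 log units; within the scatter), both fall within the scatter, so the three cannot be ordered. Compound 4 `COc1ccc(-c2cc3ccccc3nc2/C=C/C(=O)c2ccc[nH]2)cc1` differs from compound 3 by 1H-pyrrol-2-yl in place of thiophen-3-yl on a carbonyl carbon. Among the measured compounds shown here, the steps that bear on this are the earlier swaps of the group on the carbonyl carbon, a 1.1-fold lower number from compound 1 to compound 2 (0.06 log units; within the scatter), a 1.3-fold higher number from compound 1 to compound 3 (0.10 log units; within the scatter) and a 1.4-fold higher number from compound 2 to compound 3 (0.16 log units; within the scatter), none of which left the scatter. A further swap at the same place is therefore expected to give no step beyond the scatter in this assay, in either direction, the expected step being a 1.1-fold lower number from compound 3 to compound 4 (0.05 log units; within the scatter). Compound 4 is estimated at 950 nM, with a range from 450 nM to 2000 nM.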

Compound 4, half-maximal inhibitory concentration: > 10000 nM
Compound 4 gave a limit, no number; the forecaster's own chance of this, stated with the estimate: 3%; at least 10-fold (1.02 log units) between middle value and limit.
By their numbers in this assay, from the lowest: compounds 2, 1 and 3 (each within the scatter of the next). At a limit, above all of these: compound 4.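

Unlike the swaps among 4-nitrophenyl, pyridin-2-yl and thiophen-3-yl, this change shows that the group on this carbonyl carbon can matter in this assay: an at least 9.4-fold higher number from compound 3 to compound 4 (0.97 log units; beyond the scatter), an at least 13-fold higher number from compound 2 to compound 4 (1.13 log units; beyond the scatter) and an at least 11-fold higher number from compound 1 to compound 4 (1.07 log units; beyond the scatter). Compound 4 gives > 10000 nM, which is a limit of the assay and not a number. These steps therefore rest on that limit: the limit of > 10000 nM in this assay, at which 1 of the 4 values shown sits.

The compounds shown leave open whether the 1 hydrogen-bond donor of 1H-pyrrol-2-yl or some other difference in the ring goes with this step. A 1-methylpyrrol-2-yl or thiophen-2-yl group at this carbonyl carbon would help separate these readings.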